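This account rests on a few compounds, and the source may have more. Where it says the series, first, only, none or still open, it means among the compounds named here.

Three compounds share one core and differ only in their side groups. Compound 1 `N#C/N=C1\N(CCCCCCOc2ccc(Cl)cc2)C(=O)CN1c1ccncc1` gives 3860 nM in a functional assay on HA22T cells for cytotoxicity against HA22T cell line (Homo sapiens); a higher number here means a weaker inhibitor, a lower number a stronger inhibitor. Compound 2 `N#C/N=C1\N(CCCCCCCOc2ccc(Cl)cc2)C(=O)CN1c1ccncc1` gives 3500 nM in this assay. Compound 3 `CC1C(=O)N(CCCCCCOc2ccc(Cl)cc2)/C(=N\C#N)N1c1ccncc1` gives 382 nM in this assay, the lowest of the three numbers; compound 2 sits nearest to it and compound 1 furthest, and both gaps lie beyond the scatter. The two measured steps tell different stories. Lengthening the chain gives a 1.1-fold lower number from compound 1 to compound 2 (0.04 log units; within the scatter). Adding a methyl on a saturated ring carbon gives a 10-fold lower number from compound 1 to compound 3 (1.00 log units; beyond the scatter). Compound 4 `CC1C(=O)N(CCCCCCCOc2ccc(Cl)cc2)/C(=N\C#N)N1c1ccncc1` has not yet been measured. It differs from compound 3 by (4-chlorophenoxy)methyl in place of 4-chlorophenoxy on a saturated chain carbon, six bonds along the chain from an amide-type nitrogen in a ring. Among the compounds with values here, this is the same change as the one from compound 1 to compound 2, which stayed within the scatter, so no step beyond the scatter is expected in this assay. Compound 4 is therefore expected to show a 1.1-fold lower number from compound 3 to compound 4 (0.04 log units; within the scatter). Compound 4 is estimated at 350 nM, within a range from 150 nM to 900 nM.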

Compound 4, half-maximal inhibitory concentration: 688 nM
The estimate for compound 4 lay 2.0-fold (0.29 log units) below the measured number, and the stated range covers the measured number.
By their numbers in this assay, from the lowest: compounds 3 and 4 (each within the scatter of the next); then compounds 2 and 1 (each within the scatter of the next).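

With the methyl present, the exchange of 4-chlorophenoxy for (4-chlorophenoxy)methyl again stays within the scatter (a 1.8-fold higher number from compound 3 to compound 4 (0.26 log units; within the scatter)), so the insensitivity to this chain difference now holds on two cores: (the same change on two cores in this assay, a 1.1-fold lower number (0.04 log units; within the scatter) from compound 1 to compound 2 and a 1.8-fold higher number (0.26 log units; within the scatter) from compound 3 to compound 4, 2.0-fold (0.30 log units) apart, within the scatter of two such steps). The methyl on the saturated ring carbon also holds up on the longer chain (a 5.1-fold lower number from compound 2 to compound 4 (0.71 log units; beyond the scatter)), so its gain is not tied to a single chain: (the same change on two cores in this assay, a 10-fold lower number (1.00 log units; beyond the scatter) from compound 1 to compound 3 and a 5.1-fold lower number (0.71 log units; beyond the scatter) from compound 2 to compound 4, 2.0-fold (0.30 log units) apart, within the scatter of two such steps). Across these four compounds, the methyl separates compounds 3 and 4 from compounds 1 and 2, while the chain difference separates neither pair.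

The compounds shown leave open whether an ethyl or a hydroxymethyl group on that ring carbon would differ from methyl, and whether a much shorter or much longer chain would behave the same. They also leave open what fluorine or a methoxy group would do in place of the chlorine.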